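The source may report more compounds than this note shows. Statements on the series, on what has been measured and on what is new or still open speak of the compounds shown alone.

In a functional assay on A549 cells (Homo sapiens) for antiproliferative activity, read by MTT assay, with a stated time of 48 h (a higher number here means a weaker inhibitor, a lower number a stronger inhibitor), the measured compounds are:

Compound 1 `COc1ccc(CCC2=C(Cl)C(=O)c3cc(OC)cc(OC)c3C2=O)cc1`: 83100 nM
Compound 2 `COc1ccc(CCC2=C(O)C(=O)c3cc(OC)cc(OC)c3C2=O)cc1`: 82400 nM
Compound 3 `COC1=C(CCC2CCCCC2)C(=O)c2c(OC)cc(OC)cc2C1=O`: reaches only the limit of the measurement, > 100000 nM

Compound 2 and compound 1 give numbers that lie within the usual scatter of each other, so neither can be called the stronger inhibitor. For the measured compounds named here, the one measured step, a 1.0-fold lower number from compound 1 to compound 2 (0.00 log units; within the scatter), changed a group on the shared core rather than on the outer aromatic ring. Compound 4 `COc1cc(OC)c2c(c1)C(=O)C(O)=C(CCc1ccc(Br)cc1)C2=O` differs from compound 2 by bromo in place of methoxy on an aromatic carbon. Going by the values given here, no measured step touches that outer ring, so nothing here points to a move in either direction beyond the scatter. Compound 4 is therefore expected to give about 80000 nM, in a range from 30000 nM to 200000 nM. The expected step of a 1.0-fold lower number from compound 2 to compound 4 (0.01 log units; within the scatter) is estimated to stay within the scatter.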

Compound 4, half-maximal inhibitory concentration: > 100000 nM
Compound 4 ended at the assay's limit; the forecaster's own chance of this, stated with the estimate: 30%; at least 1.2-fold (0.09 log units) between middle value and limit.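

For the compounds shown here, changing 4-methoxyphenyl to 4-bromophenyl gives an at least 1.2-fold higher number from compound 2 to compound 4 (0.08 log units; that floor lies within the scatter) in this assay, the only reading at this position on the outer ring. For compound 4, > 100000 nM is a limit of the assay and not a number, so only the floor of this step can be read, and the true gap could be larger or could lie within the scatter. Compound 2 already stands close to that limit, which leaves this position little room to show any weakening: the limit of > 100000 nM in this assay, at which 2 of the 4 values shown sit.

Still open, going by these compounds, is whether another group at this position, such as an amine or a carboxylic acid, would give a clearly lower number. Whether any change on this ring can move the value away from the limit also remains unanswered.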